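From Methoxycarbonyl to 4-Methoxyphenyl in a Cell-Growth Assay

A few compounds are considered here, and "the series" means these few. Any claim that something is new, unique, unknown or untested is made for them only; others in the source may bear on it.

Compound 1 `COC(=O)c1cc(=O)c2c(OC)cc(OC)cc2[nH]1` gives only a limit in an ADME assay on BJ cells (Homo sapiens) for antiproliferative activity, with a stated time of 72 h (a higher number here means that more compound is needed for the effect, a lower number that less compound is needed), namely > 34400 nM, so no number is known for it. Compound 2 `COC(=O)c1cc(=O)c2c(OC)cc(OC)cc2n1S(=O)(=O)c1ccc(C)cc1` gives 139000 nM in this assay, and this is the only measured number among the two results shown; the other sits at the limit of > 34400 nM in this assay, at which 1 of the 2 values shown sits. Compound 3 `COc1ccc(-c2cc(=O)c3c(OC)cc(OC)cc3n2S(=O)(=O)c2ccc(C)cc2)cc1` differs from compound 2 by 4-methoxyphenyl in place of methoxycarbonyl on an aromatic carbon. Going by the values given here, no step between measured compounds exists to guide the size of this change. Compound 3 is expected to need less compound, with a step of a 7.0-fold lower number from compound 2 to compound 3 (0.84 log units; beyond the scatter). Compound 3 is estimated at 20000 nM in this assay, within 3000 nM to 139000 nM.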

Compound 3, half-maximal effective concentration: > 44800 nM
Compound 3 ended at the assay's limit; the forecaster's own chance of this, stated with the estimate: 30%; middle value at least 2.2-fold (0.35 log units) away from the limit.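

Going by these compounds alone, compound 3 gives only a limit of > 44800 nM in this assay and no step from compound 2 to compound 3 can be read. The compounds shown leave open how far 4-methoxyphenyl in place of methoxycarbonyl moves the number.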